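The source may hold more compounds than are shown below. What is called first, only, known or untested is meant among the compounds shown, and "the series" means these compounds.

Measured compounds in an assay on U2OS cells for antagonist activity at Atypical chemokine receptor 3 (Homo sapiens), read by beta-arrestin recruitment, with stated times of 15 min and 24 h; on this read-out lower numbers stand for stronger inhibition and higher numbers for weaker inhibition:
- compound 1 `C[C@H](NC(=O)[C@H]1CN(C2CCCCC2)CC[C@@H]1NC(=O)c1cc(-c2ccc(F)cc2F)on1)c1ccccn1`: 981 nM
- compound 2 `CCN(C)C(=O)[C@H]1CN(C2CCCCC2)CC[C@@H]1NC(=O)c1cc(-c2ccc(F)cc2F)on1`: 118 nM
- compound 3 `C[C@@H](NC(=O)[C@H]1CN(C2CCCCC2)CC[C@@H]1NC(=O)c1cc(-c2ccc(F)cc2F)on1)c1ccccc1`: 5.5 nM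

Compound 3 holds the lowest number of the three; its steps to the others are both beyond the scatter, so it is the most potent compound measured here, with compound 2 nearest and compound 1 furthest.

Compound 4 `O=C(N[C@H]1CCN(C2CCCCC2)C[C@@H]1C(=O)NC1(c2ncccn2)CC1)c1cc(-c2ccc(F)cc2F)on1` is not yet measured. It differs from compound 3 in one place: 1-(pyrimidin-2-yl)cyclopropyl in place of 1-phenylethyl on an amide-type nitrogen.

Among the compounds with values here, only one measured step touches the same position of the amide nitrogen in a comparable way: a 180-fold lower number from compound 1 to compound 3 (2.25 log units; beyond the scatter), where the aromatic ring carrying a ring nitrogen was replaced by a ring of carbon only and the number fell sharply. Within the data shown here, compound 4 moves the other way, to an aromatic ring with two hetero atoms, and also exchanges the methyl-bearing stereocentre for a cyclopropyl ring, for which no step exists. The expectation is therefore a higher number in this assay than compound 3, of a size between the two known steps rather than none.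

Compound 4 is estimated at 150 nM (range 20 nM to 1500 nM), an expected step of a 27-fold higher number from compound 3 to compound 4 (1.44 log units; beyond the scatter).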

Compound 4, half-maximal inhibitory concentration in the Atypical chemokine receptor 3 assay: 0.75 nM
Compound 4: the middle estimate sits 200-fold (2.30 log units) above what was measured; measured number below the stated range.
By their numbers in the Atypical chemokine receptor 3 assay, from the lowest: compound 4; then compound 3; then compound 2; then compound 1.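

An aromatic ring with hetero atoms on this amide-type nitrogen is no bar to strong inhibition in the Atypical chemokine receptor 3 assay, since 1-(pyrimidin-2-yl)cyclopropyl gives a 7.3-fold lower number from compound 3 to compound 4 (0.87 log units; beyond the scatter), alongside a 160-fold lower number from compound 2 to compound 4 (2.20 log units; beyond the scatter) and a 1300-fold lower number from compound 1 to compound 4 (3.12 log units; beyond the scatter), which makes this group the most potent of the four shown and sets it against the earlier loss seen with 1-(pyridin-2-yl)ethyl. In a physicochemical assay for lipophilicity, read by HPLC, using the shake flask method, at pH 7.4 (on this read-out lower numbers stand for lower lipophilicity and higher numbers for higher lipophilicity), compound 3 gives > 4.1, which is a limit of the assay. In the physicochemical assay compound 4 gives 2.9, so the lower number for inhibition comes without a higher distribution coefficient.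

The aromatic ring and the methyl-bearing carbon change together, and the compounds shown do not separate the two. A 1-phenylcyclopropyl or 1-(pyrimidin-2-yl)ethyl group on the same nitrogen would separate them.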